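The source may hold more compounds than are shown below. What is called first, only, known or untested is meant among the compounds shown, and "the series" means these compounds.

Compound 1, `CC1=C2CC(C)(C)/C=C/C/C(C)=C\C3=C[C@H](C)C[C@]3(O2)C1=O`, gives 26000 nM in an ADME assay on Raji cells (Homo sapiens) for cytotoxicity, read by CellTiter-Glo, with a stated time of 72 h; on this read-out higher numbers stand for an effect only at larger amounts of compound and lower numbers for an effect already at smaller amounts.
Compound 2, `CC1=C2CC(C)(C)/C=C/[C@H](O)/C(C)=C\C3=C[C@H](C)C[C@]3(O2)C1=O`, gives 26000 nM in this assay.
Compound 3, `CC(=O)O[C@H]1/C=C/C(C)(C)CC2=C(C)C(=O)[C@]3(C[C@@H](C)C=C3/C=C\1C)O2`, gives 26000 nM in this assay.

Compound 2 stands level with compounds 1 and 3 in this assay: the steps of no change at the digits printed from compound 1 to compound 2 (within the scatter), no change at the digits printed from compound 1 to compound 3 (within the scatter) and no change at the digits printed from compound 2 to compound 3 (within the scatter) all stay within the scatter, so neither a hydroxy group, nor an acetoxy group, nor an acetyl on that oxygen moved the read-out. Compound 4, `CC1=C2CC(C)(C)/C=C/[C@@H](O)/C(C)=C\C3=C[C@H](C)C[C@]3(O2)C1=O`, has not yet been measured. Compared with compound 2, (the two compounds have the same atoms and bonds and differ only in configuration as drawn: 1 of 5 stereo elements differ; a stereocentre at a saturated ring carbon is drawn S in compound 2 and R in compound 4). Among the compounds with values here, no measured step tests a change of configuration alone, yet the three flat steps show that larger changes at this carbon left the numbers unchanged. For compound 4 the expected step is therefore no change at the digits printed from compound 2 to compound 4 (within the scatter), nothing beyond the scatter. Compound 4 is estimated at 26000 nM, within a range from 13000 nM to 52000 nM.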

Compound 4, half-maximal effective concentration: 26000 nM
Compound 4: the middle estimate sits on the measured number at the digits printed; measured number inside the range.
By their numbers in this assay, from the lowest: compounds 1, 2, 3 and 4 (each within the scatter of the next).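

Reversing the hydroxy-bearing carbon from S to R gives no change at the digits printed from compound 2 to compound 4 (within the scatter) in this assay, the first test of configuration alone at this position, and that comparison is a clean one: the fact that compounds 2 and 4 differ only in the configuration as drawn. With the hydroxy group drawn R, putting it in place of hydrogen also gives no change at the digits printed from compound 1 to compound 4 (within the scatter), so both drawn configurations of this hydroxy group now sit level with the compound that lacks it. The compounds shown leave open whether an amine, a carboxylic acid or a longer chain at this carbon would move the number, and whether changes elsewhere on the shared core would.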